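Methylation of the ring nitrogen in a hydroxyphenyl purine

A few compounds are considered here, and "the series" means these few. Any claim that something is new, unique, unknown or untested is made for them only; others in the source may bear on it.

Working notes on three measured compounds in an assay on cells for displacement of a labelled ligand from adenosine receptor A1 (Homo sapiens), read by scintillation counting and radioligand binding, with a stated time of 60 min, tested at 10 uM (a higher number here means more inhibition at the concentration tested (going by the name of the read-out), a lower number less inhibition), and one to come. Going by the values given here, compound 1 `Cn1cnc2c(N3CCCCC3)nc(-c3ccccc3O)nc21` gives 50.5% and compound 2 `Cn1cnc2c(N3CCCCC3)nc(-c3cccc(O)c3O)nc21` gives 17.2%; the step of a number 33.3 percentage points lower from compound 1 to compound 2 (beyond the scatter) is the only measured step in the set. For compound 3 `Oc1cccc(-c2nc(N3CCCCC3)c3nc[nH]c3n2)c1` this assay reports only a limit, > 80%. (the limit of > 80% in this assay, at which 1 of the 3 values shown sits), so the true reading of compound 3 is not known beyond that mark.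

Compound 4 `Cn1cnc2c(N3CCCCC3)nc(-c3cccc(O)c3)nc21` differs from compound 3 in one place: methyl in place of hydrogen on an aromatic nitrogen. Among the compounds with values here, no measured step concerns a change on the ring nitrogen, and the step of a number 33.3 percentage points lower from compound 1 to compound 2 (beyond the scatter) bears on a hydroxy group on an aromatic carbon only, so it gives no direction here. Compound 1 carries the same methyl on the ring nitrogen and gives 50.5%, which is the only hint on how the methylated core reads in this assay. The expected step of a number at least 25 percentage points lower from compound 3 to compound 4 (beyond the scatter) is therefore uncertain and cannot be sized from the data. Compound 4 is estimated at 55%, with a range from 25% to 85%.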

Compound 4, a percentage reported as inhibition, at one concentration (the size of the read-out at that concentration, not a potency): 78.5%
Estimate against measurement, compound 4: 23.5 percentage points below, within the range that was stated.
By their numbers in this assay, from the lowest: compound 2; then compound 1; then compound 4. At a limit, above all of these: compound 3.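

In this assay the methyl in place of hydrogen on the aromatic nitrogen now has a measured step (a number at least 1.5 percentage points lower from compound 3 to compound 4 (that floor lies within the scatter)), but its floor lies within the scatter, so no loss from the methyl can be claimed. On the methylated core, the hydroxy arrangement on the phenyl ring now separates the compounds clearly (a number 28 percentage points higher from compound 1 to compound 4 (beyond the scatter)), and removing the added hydroxy gives a large step (a number 61.3 percentage points higher from compound 2 to compound 4 (beyond the scatter)). Compound 3 stands at a limit, so the methyl step has a floor and no measured size: the limit of > 80% in this assay, at which 1 of the 4 values shown sits.

As far as these compounds go, the true size of the methyl step stays open. So does how an ethyl group or a longer chain on the ring nitrogen, or an amine or carboxylic acid in place of the hydroxy on the phenyl ring, would read in this assay.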